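The source may report more compounds than this note shows. Statements on the series, on what has been measured and on what is new or still open speak of the compounds shown alone.

In a functional assay on HepG2 cells (Homo sapiens) for inhibition, read by MTT assay, with a stated time of 48 h (on this read-out lower numbers stand for stronger inhibition and higher numbers for weaker inhibition), compound 1 `COc1ccc(-n2c(SC)nnc2-c2cc(OC)c(OC)c(OC)c2)cc1` gives > 60000 nM, which is a limit. Compound 2 `CCSc1nnc(-c2cc(OC)c(OC)c(OC)c2)n1-c1ccc(OC)cc1` gives > 60000 nM, also a limit. Compound 3 `CCSc1nnc(-c2cc(OC)c(OC)c(OC)c2)n1-c1ccc(N(C)C)cc1` gives > 60000 nM, again a limit, so it has no exact position in this assay. Among the compounds with values here, the series so far shows (the limit of > 60000 nM in this assay, at which 3 of the 3 values shown sit).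

Compound 4 `COc1cc(-c2nnc(SCC(=O)c3ccc(F)cc3)n2-c2ccc(N(C)C)cc2)cc(OC)c1OC` carries (4-fluorophenyl)carbonyl in place of methyl on a saturated chain carbon bound to a sulfur, which turns ethylsulfanyl into (((4-fluorophenyl)carbonyl)methyl)sulfanyl. The measured steps that bear on it are a step that the two limits leave unreadable from compound 1 to compound 2, also on a saturated chain carbon bound to a sulfur, and a step that the two limits leave unreadable from compound 2 to compound 3. Neither gives a size to carry over.

The estimated at least 5.0-fold lower number from compound 3 to compound 4 (0.69 log units; beyond the scatter) points towards stronger inhibition, with no measured support for its size. Compound 4 is expected at 12000 nM, with an estimated range of 1000 nM to 60000 nM.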

Compound 4, half-maximal inhibitory concentration: > 60000 nM
Compound 4: only a limit was reported; the forecaster's own chance of this, stated with the estimate: 35%; middle value at least 5.0-fold (0.69 log units) away from the limit.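

Compound 3 and compound 4 both sit at a limit, so the step between them cannot be read: the limit of > 60000 nM in this assay, at which 4 of the 4 values shown sit.

The compounds shown leave open how large any of these changes is, and whether any of them gives an exact value.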